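Swapping the urea aryl group in a pyrimidine urea series

The source may report more compounds than this note shows. Statements on the series, on what has been measured and on what is new or still open speak of the compounds shown alone.

Measured compounds:
- Compound 1, `COc1cc(NC(=O)Nc2cc(Nc3cc(F)ccc3OC)ncn2)cc(OC)c1`: 42.1%
- Compound 2, `COc1cc(NC(=O)Nc2cc(Nc3cc(C(F)(F)F)ccc3OC)ncn2)cc(OC)c1`: 67.1%
- Compound 3, `COc1ccc(Nc2cc(NC(=O)Nc3c(Cl)cccc3Cl)ncn2)cc1C`: 45.1%

In a functional assay on NCI-H1581 cells (Homo sapiens) for inhibition, read by MTT assay, with a stated time of 48 h, tested at 10 uM (on this read-out higher numbers stand for more inhibition at the one concentration tested (going by the name of the read-out) and lower numbers for less inhibition), compound 2 gives the highest of the three numbers; compound 3 lies beyond the scatter below it, and compound 1 further still. Among the compounds with values here, the one counted step, a number 25 percentage points higher from compound 1 to compound 2 (beyond the scatter), changes the aryl group on the aniline side, not the urea side, so it does not bear on the change considered here.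

Compound 4, `COc1ccc(C(F)(F)F)cc1Nc1cc(NC(=O)Nc2c(Cl)cccc2Cl)ncn1`, differs from compound 2 in one place: 2,6-dichlorophenyl in place of 3,5-dimethoxyphenyl on an amide-type nitrogen. Within the data shown here, no measured pair isolates this change. Compound 3 carries the same 2,6-dichlorophenyl on its urea nitrogen but a different aniline, so its value only hints that this group sits in the middle of the measured range. Compound 4 is therefore expected to come out as a number 12.1 percentage points lower from compound 2 to compound 4 (beyond the scatter), with wide uncertainty. The estimate for compound 4 in this assay is 55%, within a range of 35% to 75%.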

Compound 4, a percentage reported as inhibition, at one concentration (the size of the read-out at that concentration, not a potency): 69.1%
Estimate against measurement, compound 4: 14.1 percentage points below; the measured number falls inside the stated range.
By their numbers in this assay, from the lowest: compounds 1 and 3 (each within the scatter of the next); then compounds 2 and 4 (each within the scatter of the next).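

In this assay, the urea aryl group now has its first direct reading: a number 2 percentage points higher from compound 2 to compound 4 (within the scatter). With the rest of the structure held fixed, 2,6-dichlorophenyl and 3,5-dimethoxyphenyl on the amide-type nitrogen therefore cannot be told apart here, even though the exchange replaces two methoxy groups with two chlorines. Nothing available explains why these two groups read alike.

As far as these compounds go, whether they also read alike when the trifluoromethyl on the aniline side is replaced by fluoro, as in compound 1, remains open. It is also open how this nitrogen would respond to a plain phenyl or to an aryl group carrying a carboxylic acid or a morpholine, and a single concentration gives no potency for any of these compounds.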